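This account rests on a few compounds, and the source may have more. Where it says the series, first, only, none or still open, it means among the compounds named here.

In a functional assay on cells for antagonist activity at Glucagon receptor (Homo sapiens), read by cAMP accumulation, in the presence of a further agent that is not named here (on this read-out higher numbers stand for weaker inhibition and lower numbers for stronger inhibition), compound 1 (`CCCC(Oc1ccc(-n2cc(C(F)(F)F)c(C)n2)cc1)c1ccc(C(=O)NCCC(=O)O)cc1`) gives 8300 nM. Of the two numbers in hand, that is the higher one: compound 2 (`CCCC(Nc1cc(C)c(-n2cc(C(F)(F)F)cn2)c(C)c1)c1ccc(C(=O)NCCC(=O)O)cc1`) gives 1400 nM, a lower number that stands for stronger inhibition. Compound 3 (`CCC(Oc1ccc(-n2cc(C(F)(F)F)cn2)cc1)c1ccc(C(=O)NCCC(=O)O)cc1`) gives > 22000 nM, which is a limit of this assay and not a number, as set out in the limit of > 22000 nM in this assay, at which 1 of the 3 values shown sits. Within the data shown here, compound 2 and compound 3 each differ from compound 1 in more than one place, so no single step between them is worked out here.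

Compound 4 (`CCCC(Oc1ccc(-n2cccn2)cc1)c1ccc(C(=O)NCCC(=O)O)cc1`) is a single change away from compound 1: 1H-pyrazol-1-yl in place of 3-methyl-4-(trifluoromethyl)-1H-pyrazol-1-yl on an aromatic carbon. Among the measured compounds shown here, no measured pair shows such a step, so the expectation rests on compound 1 standing at 8300 nM. It rests also on compound 3, which likewise carries a plain pyrazole and already sits at a limit. In this assay compound 4 is expected to show a step of a 3.0-fold higher number from compound 1 to compound 4 (0.48 log units; beyond the scatter), toward weaker inhibition and likely beyond the scatter. Compound 4 is therefore estimated at 25000 nM, in a range from 8000 nM to 80000 nM, with a fair chance that only a limit is reported.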

Compound 4, antagonist equilibrium constant: > 55000 nM
Compound 4 was reported as a limit; the forecaster's own chance of this, stated with the estimate: 55%; middle value at least 2.2-fold (0.34 log units) away from the limit.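

Compound 4 is reported only as a limit of the assay and not as a number: the limit of > 55000 nM in this assay, at which 1 of the 4 values shown sits.

Among these compounds, this gives the first comparison here that changes a single place, and in this assay replacing 3-methyl-4-(trifluoromethyl)-1H-pyrazol-1-yl with 1H-pyrazol-1-yl gives an at least 6.6-fold higher number from compound 1 to compound 4 (0.82 log units; beyond the scatter), toward weaker inhibition. The pyrazole ring itself stays, so on this core the loss of inhibition goes with removing the methyl and trifluoromethyl groups from it, and the bare ring does not keep the inhibition seen with the substituted one. The step is a minimum, and its full size cannot be read.

Which of the two groups, methyl or trifluoromethyl, accounts for more of the step stays open. So does whether another group on the pyrazole, such as a chlorine atom or a nitrile, would hold or improve the inhibition of compound 1.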